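Pendant amine substituent swap on the shared core

The source may hold more compounds than are shown below. What is called first, only, known or untested is meant among the compounds shown, and "the series" means these compounds.

For the measured compounds named here, compound 3 `C(=C/CN(C[C@H]1Cc2ccccc2CN1)[C@H]1CCCc2cccnc21)\CNCC1CCOCC1` is the reference point: in a functional assay on cells for antagonist activity at C-X-C chemokine receptor type 4 (Homo sapiens), read by fluorescence and calcium flux, with stated times of 25 min and 90 s (a higher number here means a weaker inhibitor, a lower number a stronger inhibitor), compound 3 gives 24.2 nM, the lowest of the numbers so far. Compound 1 `NCc1ccccc1CN(C[C@H]1Cc2ccccc2CN1)[C@H]1CCCc2cccnc21` gives 50.8 nM in this assay. Between them the step is a 2.1-fold lower number from compound 1 to compound 3 (0.32 log units; beyond the scatter). Compound 2 `CC(C)(CCN)CN(C[C@H]1Cc2ccccc2CN1)[C@H]1CCCc2cccnc21` reaches only a limit of the assay, > 33300 nM in this assay (the limit of > 33300 nM in this assay, at which 1 of the 3 values shown sits). Two further steps are known: an at least 650-fold higher number from compound 1 to compound 2 (2.81 log units; beyond the scatter) and an at least 1300-fold lower number from compound 2 to compound 3 (3.13 log units; beyond the scatter).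

Compound 4 `C(=C/CN(C[C@H]1Cc2ccccc2CN1)[C@H]1CCCc2cccnc21)\CNCc1ccccn1` differs from compound 3 by pyridin-2-yl in place of oxan-4-yl on a saturated chain carbon bound to an amine nitrogen. The step that bears most on this is the modest one, a 2.1-fold lower number from compound 1 to compound 3 (0.32 log units; beyond the scatter), where a six-membered aromatic ring of carbon only gave way to the oxan-4-yl-bearing group; the large steps into and out of compound 2, where no ring was present, are less comparable, since compound 4 keeps a six-membered ring, now aromatic with one hetero atom. The change thus resembles a return toward compound 1 rather than toward compound 2, so in this assay a step about the size of that between compound 1 and compound 3, in the opposite direction, or none beyond the scatter is expected. Compound 4 is therefore estimated at 35 nM in this assay, between 12 nM and 100 nM, an expected step of a 1.4-fold higher number from compound 3 to compound 4 (0.16 log units; within the scatter).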

Compound 4, half-maximal inhibitory concentration: 58.3 nM
Beside the measured number, compound 4's estimate is 1.7-fold (0.22 log units) below it; the measured number falls inside the stated range.
By their numbers in this assay, from the lowest: compound 3; then compounds 1 and 4 (each within the scatter of the next). At a limit, above all of these: compound 2.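

On a saturated chain carbon bound to an amine nitrogen, the change from oxan-4-yl to pyridin-2-yl is not silent in this assay: it gives a 2.4-fold higher number from compound 3 to compound 4 (0.38 log units; beyond the scatter), so the group on this chain does shift the number even when the ring size stays the same. With the pyridin-2-yl group, the unsaturated chain gives a result level with the pendant group of the earlier aromatic compound, a 1.1-fold higher number from compound 1 to compound 4 (0.06 log units; within the scatter), so these two cannot be ordered. The distance from the ringless group stays large, an at least 570-fold lower number from compound 2 to compound 4 (2.75 log units; beyond the scatter), and that step is read from a limit held by compound 2: the limit of > 33300 nM in this assay, at which 1 of the 4 values shown sits.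

On these data alone, the step from compound 3 to compound 4 changes the ring's aromatic character and its hetero atom together, so the share of each stays open. A phenyl or piperidin-4-yl group on the same carbon would separate them, and pyridin-3-yl or pyridin-4-yl would test where the ring nitrogen stands.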